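A few compounds are considered here, and "the series" means these few. Any claim that something is new, unique, unknown or untested is made for them only; others in the source may bear on it.

Compound 1, `Cc1c(OCCCCOc2ccccc2C(=O)O)ccc(C(=O)CC2CCCC2)c1C`, gives 67.1% in an assay on HEK293 cells for positive allosteric modulation of metabotropic glutamate receptor 2 (Rattus norvegicus), read by thallium flux, with a stated time of 2.5 min; a lower number here means a smaller maximal response, a higher number a larger maximal response. Compound 2, `COC(=O)c1ccc(OCCCCOc2ccc(C(=O)CC3CCCC3)c(C)c2C)cc1`, carries the change 4-(methoxycarbonyl)phenyl in place of 2-carboxyphenyl on an oxygen on a saturated carbon and gives 14.1% in this assay; the step of a number 53 percentage points lower from compound 1 to compound 2 (beyond the scatter) is the one clear effect seen among the measured compounds. Compound 3, `Cc1c(OCCCCOc2ccccc2C(=O)O)ccc(C(=O)CC(C)C)c1C`, differs from compound 1 in its core by isopropyl in place of cyclopentyl on a saturated chain carbon bound to a carbonyl carbon; in this assay compound 3 gives 76.2%, and the step of a number 9.1 percentage points higher from compound 1 to compound 3 (within the scatter) does not separate the two.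

Compound 4, `COC(=O)c1ccc(OCCCCOc2ccc(C(=O)CC(C)C)c(C)c2C)cc1`, is not yet measured. It stands to compound 3 as compound 2 stands to compound 1: the change 4-(methoxycarbonyl)phenyl in place of 2-carboxyphenyl on an oxygen on a saturated carbon is the same change, made on the same place, and it occurs twice among these compounds. Because the step of a number 53 percentage points lower from compound 1 to compound 2 (beyond the scatter) was large, compound 4 is expected to show a step of similar size, a number 54.2 percentage points lower from compound 3 to compound 4 (beyond the scatter), against compound 3, the only support being that single earlier pair. Compound 4 is therefore estimated at 22% in this assay, with the range 8% to 40% allowing for the usual spread of such readings.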

Compound 4, largest response reached (reported as percent of maximum), in percent of the reference or control that the assay uses: 15.9%
The estimate for compound 4 lay 6.1 percentage points above the measured number, within the range that was stated.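

In this assay, the exchange of 2-carboxyphenyl for 4-(methoxycarbonyl)phenyl carries over to a second core, where it gives a number 60.3 percentage points lower from compound 3 to compound 4 (beyond the scatter), and the earlier step is matched in size: the same change on two cores in this assay, a number 53 percentage points lower (beyond the scatter) from compound 1 to compound 2 and a number 60.3 percentage points lower (beyond the scatter) from compound 3 to compound 4, 7.3 percentage points apart, within the scatter of two such steps. The other change, isopropyl in place of cyclopentyl, also behaves alike on both sides, with a number 1.8 percentage points higher from compound 2 to compound 4 (within the scatter) leaving the two esters unseparated: the same change on two cores in this assay, a number 9.1 percentage points higher (within the scatter) from compound 1 to compound 3 and a number 1.8 percentage points higher (within the scatter) from compound 2 to compound 4, 7.3 percentage points apart, within the scatter of two such steps. Among the compounds shown here, this agreement rests on only two pairs of closely related compounds, and it does not show which part of the exchange goes with the large step, as the group on the ring and the place it occupies differ together.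

The compounds shown leave open how 4-carboxyphenyl and 2-(methoxycarbonyl)phenyl would compare, and these two groups would separate the group's identity from its place on the ring. Also open, as far as these compounds go, is whether the step would hold with a phenyl or a longer chain in place of the isopropyl and cyclopentyl groups.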